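The source may hold more compounds than are shown below. What is called first, only, known or untested is meant among the compounds shown, and "the series" means these compounds.

Working notes on the series. Compound 1 `O=c1ccc(=O)c2c1c1[nH]c3ccccc3c1c1c(=O)[nH]c(=O)c21` gives 6800 nM in a functional assay on L1210 cells (Mus musculus) for antiproliferative activity, with a stated time of 4 h; on this read-out lower numbers stand for stronger inhibition and higher numbers for weaker inhibition. Compound 2 `Cc1ccc2[nH]c3c4c(=O)ccc(=O)c4c4c(=O)[nH]c(=O)c4c3c2c1` carries methyl in place of hydrogen on an aromatic carbon and in this assay compound 2 gives 750 nM; the resulting step is a 9.1-fold lower number from compound 1 to compound 2 (0.96 log units; beyond the scatter). Compound 3 `O=C1NC(=O)c2c1c1c(O)ccc(O)c1c1[nH]c3ccccc3c21` rests on a different core, and the difference between the two cores is not broken down here; in this assay compound 3 gives 1100 nM. Compound 4 `Cc1ccc2[nH]c3c4c(O)ccc(O)c4c4c(c3c2c1)C(=O)NC4=O` is the unmeasured partner of compound 3 and carries methyl in place of hydrogen on an aromatic carbon, the same change as between compound 1 and compound 2. Within the data shown here, because the only measured instance of this change is a 9.1-fold lower number from compound 1 to compound 2 (0.96 log units; beyond the scatter), and it sits on a different core, a step of the same direction but tempered size is expected from compound 3 to compound 4, namely a 4.4-fold lower number from compound 3 to compound 4 (0.64 log units; beyond the scatter). For compound 4 the expected value is 250 nM, within 80 nM to 800 nM.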

Compound 4, half-maximal inhibitory concentration: 600 nM
Beside the measured number, compound 4's estimate is 2.4-fold (0.38 log units) below it; measured number inside the range.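

Methyl in place of hydrogen on an aromatic carbon gives a 1.8-fold lower number from compound 3 to compound 4 (0.26 log units; within the scatter) in this assay, so the clear step seen on the core of compound 1 does not carry over at full size to the core of compound 3. The two instances differ by more than their scatter: the same change on two cores in this assay, a 9.1-fold lower number (0.96 log units; beyond the scatter) from compound 1 to compound 2 and a 1.8-fold lower number (0.26 log units; within the scatter) from compound 3 to compound 4, 4.9-fold (0.69 log units) apart, beyond the scatter of two such steps. This shows that the size of the step depends on the core for these two cores, but the second step is too small to confirm its direction, and two cores neither explain the difference nor predict the result on a third.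

Going by these compounds, it remains open whether an ethyl group, a methoxy group or an amine on the same aromatic carbon would also give steps that differ between the two cores.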